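Bromo for methyl on a fused indoline-type core

A few compounds are considered here, and "the series" means these few. Any claim that something is new, unique, unknown or untested is made for them only; others in the source may bear on it.

Measured compounds:
compound 1, `COC(=O)[C@@]1(C)CCC=C2[C@@H]1CC[C@@H](C)[C@]2(C)Cc1c[nH]c2ccc(C)cc12`, 17000 nM;
compound 2, `COC(=O)[C@@]1(C)CCC=C2[C@@H]1CC[C@@H](C)[C@]2(C)Cc1c[nH]c2ccc(Br)cc12`, 15000 nM;
compound 3, `COC(=O)[C@@]1(C)CC[C@@H]2C3=C1CC[C@@H](C)[C@]3(C)C[C@@H]1c3cc(C)ccc3N[C@H]21`, 27000 nM.

All three were tested in a functional assay on A549 cells (Homo sapiens) for inhibition, read by sulforhodamine B assay, with a stated time of 48 h; on this read-out lower numbers stand for stronger inhibition of growth and higher numbers for weaker inhibition of growth. Compound 1 and compound 2 share one core and differ by the change (bromo in place of methyl on an aromatic carbon), which gave a 1.1-fold lower number from compound 1 to compound 2 (0.05 log units; within the scatter). Compound 3 carries a different core; the difference between the two cores is not broken down here. Compound 4, `COC(=O)[C@@]1(C)CC[C@@H]2C3=C1CC[C@@H](C)[C@]3(C)C[C@@H]1c3cc(Br)ccc3N[C@H]21`, is made from compound 3 by the change (bromo in place of methyl on an aromatic carbon). Among the compounds with values here, this is the same kind of change as the one from compound 1 to compound 2, though the place differs: there the six-membered aromatic ring is part of a fused or bridged system of two rings, here of five rings. Because the earlier step was a 1.1-fold lower number from compound 1 to compound 2 (0.05 log units; within the scatter), a step of similar size is expected from compound 3 to compound 4 in this assay, namely a 1.1-fold lower number from compound 3 to compound 4 (0.05 log units; within the scatter). Compound 4 is therefore expected to give about 24000 nM, between 12000 nM and 50000 nM.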

Compound 4, concentration for 50% growth inhibition: 40000 nM
The estimate for compound 4 lay 1.7-fold (0.22 log units) below the measured number, and the stated range covers the measured number.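

In this assay, bromo in place of methyl on the core of compound 3 gave a 1.5-fold higher number from compound 3 to compound 4 (0.17 log units; within the scatter). Set beside the earlier step, the change shows no difference that can be told apart between the two cores: the same change on two cores in this assay, a 1.1-fold lower number (0.05 log units; within the scatter) from compound 1 to compound 2 and a 1.5-fold higher number (0.17 log units; within the scatter) from compound 3 to compound 4, 1.7-fold (0.23 log units) apart, within the scatter of two such steps. This shows that neither core gives a step beyond the scatter for this one change, but it does not show that the two steps are equal or that the same would hold on any other core.

Only methyl and bromo are shown on this aromatic carbon. On these data alone, whether a chloro, a methoxy, a nitrile or a carboxylic acid there would give a larger step on either core remains open.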